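A few compounds are considered here, and "the series" means these few. Any claim that something is new, unique, unknown or untested is made for them only; others in the source may bear on it.

Measured so far:
compound 1 (`COc1cccc(/C=C/C(=O)C(=Cc2ccc(OC)c(OC)c2OC)C(=O)/C=C/c2cccc(OC)c2OC)c1OC`) gives 560 nM
compound 2 (`COc1cc(OC)c(/C=C/C(=O)C(=Cc2ccc(O)c(OC)c2)C(=O)/C=C/c2c(OC)cc(OC)cc2OC)c(OC)c1`) gives 1490 nM

Both values come from a functional assay on SW480 cells (Homo sapiens) for antiproliferative activity, read by sulforhodamine B assay, with a stated time of 48 h (on this read-out lower numbers stand for stronger inhibition and higher numbers for weaker inhibition), and, of the two numbers, compound 2 has the higher, with compound 1 lower by a gap beyond the scatter. Compound 3 (`COc1cc(OC)c(/C=C/C(=O)C(=Cc2cc(Br)c(O)c(OC)c2)C(=O)/C=C/c2c(OC)cc(OC)cc2OC)c(OC)c1`) is compound 2 with bromo in place of hydrogen on an aromatic carbon, ortho to a hydroxy group (bromo in place of hydrogen on an aromatic carbon). The 4-hydroxy-3-methoxyphenyl thus becomes 3-bromo-4-hydroxy-5-methoxyphenyl. Going by the values given here, no measured pair differs in one place only, so the series offers no direct guide to this change. In this assay no step beyond the scatter is expected, and the direction remains uncertain. The expected change is a 1.4-fold lower number from compound 2 to compound 3 (0.13 log units; within the scatter) as an estimate. Compound 3 is estimated at 1100 nM in a range of 450 nM to 2700 nM for now.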

Compound 3, half-maximal inhibitory concentration: 1450 nM
Compound 3: the middle estimate sits 1.3-fold (0.12 log units) below what was measured, and the stated range covers the measured number.
By their numbers in this assay, from the lowest: compound 1; then compounds 3 and 2 (each within the scatter of the next).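

In this assay, bromo in place of hydrogen on an aromatic carbon, ortho to a hydroxy group, gives a 1.0-fold lower number from compound 2 to compound 3 (0.01 log units; within the scatter). Going by these compounds alone, this is the first comparison that differs in one place only, and it shows that this aromatic carbon carries a bromine with no step beyond the scatter. No measured evidence bearing on this result is available.

Open, on these data alone, is whether this holds only for bromo or also for other groups on the same carbon, such as an amine, a carboxylic acid or a longer chain. Also open, as far as these compounds go, is whether the same tolerance holds for the same change in the 3-bromo-4-hydroxy-5-methoxyphenyl setting with the hydroxy group replaced by another group.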